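From an Ethynyl Sulfide to a Benzothiophene Sulfide

The compounds below may be only part of what the source reports. "The series", "measured", "known", "first", "only" and "open" are said of these compounds alone.

Compound 3 `C#CSc1nc2nc(C)cc(N3CC[C@@H](C)[C@@H](N(C)c4ncnc5[nH]ccc45)C3)n2n1` carries an ethynyl on the sulfur of the shared core. In a toxicity assay on GES1 cells (Homo sapiens) for inhibition, read by MTT assay, with a stated time of 72 h (on this read-out lower numbers stand for stronger inhibition and higher numbers for weaker inhibition), compound 3 gives > 100000 nM, which is a limit of the assay and not a number. Compound 1 `CCCSc1nc2nc(C)cc(N3CC[C@@H](C)[C@@H](N(C)c4ncnc5[nH]ccc45)C3)n2n1`, the propyl analogue, gives 67100 nM in this assay. Compound 2 `Cc1cc(N2CC[C@@H](C)[C@@H](N(C)c3ncnc4[nH]ccc34)C2)n2nc(SCc3ccccc3Br)nc2n1`, with a 2-bromobenzyl on the sulfur, gives > 100000 nM in this assay, again a limit. The step of an at least 1.4-fold higher number from compound 1 to compound 3 (0.17 log units; that floor lies within the scatter) and the step of an at least 1.4-fold higher number from compound 1 to compound 2 (0.17 log units; that floor lies within the scatter) both end at that limit, and the step that the two limits leave unreadable from compound 2 to compound 3 cannot be sized because the limit of > 100000 nM in this assay, at which 2 of the 3 values shown sit, caps both of its ends.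

Compound 4 `Cc1cc(N2CC[C@@H](C)[C@@H](N(C)c3ncnc4[nH]ccc34)C2)n2nc(SCc3csc4ccc(Cl)cc34)nc2n1` is the compound not yet measured. Its change from compound 3 is (5-chloro-1-benzothiophen-3-yl)methyl in place of ethynyl on a sulfur. The closest measured comparison is that between compound 2 and compound 3, where a ring-bearing group on a saturated chain carbon bound to a sulfur and an ethynyl on a sulfur both sit at the limit, so no direction can be read from it. The account therefore expects compound 4 to remain at the limit as well, with a number no higher from compound 3 to compound 4 (the limit leaves the size open) expected to be no step beyond the scatter. Compound 4 is estimated to give 100000 nM, within a range from 45000 nM to 250000 nM.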

Compound 4, half-maximal inhibitory concentration: > 100000 nM
Compound 4: a limit, no number (the forecaster's own chance of this, stated with the estimate: 70%); the middle value lies on the limit itself.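

Compound 4 shows that a much larger group on this sulfur, the (5-chloro-1-benzothiophen-3-yl)methyl with its two aromatic rings and its chlorine, also ends at a limit of the assay and not at a number, as the ethynyl of compound 3 and the 2-bromobenzyl of compound 2 did. Among these compounds, compound 1, with its propyl, is the only one of the four with a number in this assay, yet the one readable new step, an at least 1.4-fold higher number from compound 1 to compound 4 (0.17 log units; that floor lies within the scatter), does not set it apart from compound 4. The steps joining compound 4 to compound 2 and to compound 3 cannot be read, because a single limit caps both ends of each: the limit of > 100000 nM in this assay, at which 3 of the 4 values shown sit.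

From the compounds shown here alone, how far compound 2, compound 3 and compound 4 lie beyond that limit stays open, and so does any order among them. Also open, going by these compounds, is whether a different kind of group on this sulfur, such as an amine or a carboxylic acid, would give a clearly lower number in this assay.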